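A few compounds are considered here, and "the series" means these few. Any claim that something is new, unique, unknown or untested is made for them only; others in the source may bear on it.

Compound 1 `COc1ccccc1-c1csc2cnc(Nc3ccc(NC(=O)C4CCNCC4)cc3)nc12` gives 450 nM in a functional assay on A549 cells (Homo sapiens) for inhibition, read by MTT assay, with a stated time of 72 h (a lower number here means a stronger inhibitor, a higher number a weaker inhibitor), the lowest of the three numbers in hand. Compound 2 `COc1ccccc1-c1csc2cnc(Nc3ccc(C(=O)NC4CCNCC4)cc3C)nc12` gives 3420 nM and compound 3 `COc1ccccc1-c1csc2cnc(Nc3ccc(C(=O)NC4CCNCC4)cc3C(F)(F)F)nc12` gives 4110 nM, both well beyond the scatter above compound 1. Among the compounds with values here, the only step measured between two compounds differing in one place is a 1.2-fold higher number from compound 2 to compound 3 (0.08 log units; within the scatter), which does not concern the change now followed. Compound 4 `COc1ccccc1-c1csc2cnc(Nc3ccc(C(=O)NC4CCNCC4)cc3)nc12` differs from compound 1 by (piperidin-4-yl)carbamoyl in place of ((piperidin-4-yl)carbonyl)amino on an aromatic carbon. Within the data shown here, compounds 2 and 3 carry this same carbamoyl arrangement but also an added methyl or trifluoromethyl on an aromatic carbon, so no step in hand isolates the reversal of the amide alone. Compound 4 is therefore expected to show a step of a 3.3-fold higher number from compound 1 to compound 4 (0.52 log units; beyond the scatter), a weaker inhibition than compound 1. For compound 4 the estimate is 1500 nM, with a range from 500 nM to 4500 nM.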

Compound 4, half-maximal inhibitory concentration: 360 nM
Compound 4: the middle estimate sits 4.2-fold (0.62 log units) above what was measured, outside the stated range (below it).
By their numbers in this assay, from the lowest: compounds 4 and 1 (each within the scatter of the next); then compounds 2 and 3 (each within the scatter of the next).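

Swapping ((piperidin-4-yl)carbonyl)amino for (piperidin-4-yl)carbamoyl does not separate the two amide arrangements in this assay, with a 1.3-fold lower number from compound 1 to compound 4 (0.10 log units; within the scatter). The unsubstituted compound 4 also isolates the added groups, giving a 9.5-fold lower number from compound 2 to compound 4 (0.98 log units; beyond the scatter) and an 11-fold lower number from compound 3 to compound 4 (1.06 log units; beyond the scatter), so the higher numbers of compound 2 and compound 3 go with methyl and trifluoromethyl, not with the carbamoyl arrangement. No measurement at hand accounts for these steps. Still open, on these data alone, is whether a fluorine or a methoxy group in place of methyl would give such a large step, and whether an N-methylpiperidine would keep the number of compound 4.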